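This account rests on a few compounds, and the source may have more. Where it says the series, first, only, none or still open, it means among the compounds named here.

Measured compounds:
Compound 1, `CC1=CC[C@H](C(C)(C)NC(=S)NN)CC1`, gives 49500 nM.
Compound 2, `CC1=CC[C@H](C(C)(C)NC(=S)N/N=C/c2ccccc2O)CC1`, gives 3100 nM.

Both numbers come from an ADME assay on Vero cells (Chlorocebus sabaeus) for inhibition, read by sulforhodamine B assay, with a stated time of 48 h; a higher number here means a weaker inhibitor of growth, a lower number a stronger inhibitor of growth. Compound 1 stands highest of the two numbers; its nearest neighbour is compound 2, whose number sits lower by a gap beyond the usual scatter. Within the data shown here, no step between measured compounds that differ in one place is recorded, so nothing more than the two values themselves can be read from this pair.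

Compound 3, `CC1=CC[C@H](C(C)(C)NC(=S)N/N=C/c2ccc[nH]2)CC1`, has not yet been measured. It differs from compound 1 by a group of 7 heavy atoms (5 carbon, 2 nitrogen; one five-membered aromatic ring with 1 hetero atom) in place of one nitrogen atom, on an amide-type nitrogen. Compound 3 is expected to show a step from compound 1 of the size an 8.3-fold lower number from compound 1 to compound 3 (0.92 log units; beyond the scatter), toward a lower number and beyond the scatter, because compound 2 gives 3100 nM. The estimate for compound 3 in this assay is 6000 nM, with the likely range running from 2000 nM to 20000 nM; this rests on two measured compounds only and remains an expectation.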

Compound 3, concentration for 50% growth inhibition: 20500 nM
Compound 3: the middle estimate sits 3.4-fold (0.53 log units) below what was measured, outside the stated range (above it).
By their numbers in this assay, from the lowest: compound 2; then compound 3; then compound 1.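

In this assay, a five-membered aromatic ring carried on the amide-type nitrogen through a carbon with a double bond to nitrogen, in place of the amino group, gives a 2.4-fold lower number from compound 1 to compound 3 (0.38 log units; beyond the scatter) and so shows that a lower number at this position does not depend on the 2-hydroxyphenyl group of compound 2. The aryl group itself still counts, since 1H-pyrrol-2-yl in place of 2-hydroxyphenyl on that same carbon gives a 6.6-fold higher number from compound 2 to compound 3 (0.82 log units; beyond the scatter) and leaves compound 3 much nearer to compound 1 than to compound 2 on the printed values. No measurement at hand bears on the reason for this difference between the two groups.

The compounds shown leave open whether the hydroxyl of the 2-hydroxyphenyl group is what separates compound 2 from compound 3, a question that an unsubstituted phenyl group in that place would address. They also leave open how a furan-2-yl or pyridin-2-yl group would compare there, and whether a carbonyl in place of the thiocarbonyl would keep these steps.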